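The compounds below may be only part of what the source reports. "The series", "measured", "known", "first", "only" and "open" are said of these compounds alone.

Compound 1 `Cc1cc(=O)oc2cc(OC(C)(C)[C@@H](COC(=O)[C@@]34CC[C@@](C)(C(=O)O3)C4(C)C)OC(=O)[C@@]34CC[C@@](C)(C(=O)O3)C4(C)C)ccc12`: 39200 nM
Compound 2 `Cc1cc(=O)oc2c([C@H](C)OC(=O)[C@@]34CC[C@@](C)(C(=O)O3)C4(C)C)c(OC(C)C)ccc12`: 56500 nM

In an ADME assay on MT2 cells (Homo sapiens) for cytotoxicity, read by XTT assay, with a stated time of 6 days (a lower number here means a stronger inhibitor, a higher number a weaker inhibitor), compound 2 gives 56500 nM, the higher number of the two but within the usual scatter of compound 1 at 39200 nM. Compound 3 `Cc1cc(=O)oc2c(COC(=O)[C@@]34CC[C@@](C)(C(=O)O3)C4(C)C)c(OC(C)C)ccc12` differs from compound 2 at one place: hydrogen in place of methyl on a saturated chain carbon bound to an aromatic carbon and an oxygen next to a carbonyl group. Within the data shown here, no measured pair shows this change, so no step beyond the scatter is expected in this assay. The estimated 1.3-fold lower number from compound 2 to compound 3 (0.10 log units; within the scatter) is expected to stay within the scatter. Compound 3 is estimated at 45000 nM, with an expected range of 18000 nM to 100000 nM.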

Compound 3, half-maximal inhibitory concentration: 58400 nM
Compound 3: middle estimate off by 1.3-fold (0.11 log units), on the low side; the measured number falls inside the stated range.
By their numbers in this assay, from the lowest: compounds 1, 2 and 3 (each within the scatter of the next).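

In this assay, among these compounds, hydrogen in place of methyl on a saturated chain carbon bound to an aromatic carbon and an oxygen next to a carbonyl group gives a 1.0-fold higher number from compound 2 to compound 3 (0.01 log units; within the scatter) as the first measured step at this position. At this carbon, then, the methyl group can be absent without the number leaving the scatter, something compound 1 and compound 2 alone could not show. No measurement on hand bears on this result. The compounds shown leave open whether an ethyl group, a hydroxyl group or an amine at this carbon would give a step beyond the scatter.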